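This account rests on a few compounds, and the source may have more. Where it says the series, first, only, none or still open, it means among the compounds named here.

Compound 1 `O=C(O)c1ccc(-c2cnc(C(=O)CCc3ccc(-c4ccccc4)cc3)o2)cn1` gives 44 nM in an assay for inhibition of Fatty-acid amide hydrolase 1 (Rattus norvegicus) (a higher number here means a weaker inhibitor, a lower number a stronger inhibitor), the lower of the two numbers recorded so far. Compound 2 `COC(=O)c1ccc(-c2cnc(C(O)CCc3ccc(-c4ccccc4)cc3)o2)nc1`, a hydroxy analogue with an ester and a differently placed ring nitrogen, gives 1100 nM in this assay, a gap beyond the scatter. Compound 3 `CS(=O)(=O)c1cnc(C(=O)CCc2ccc(-c3ccccc3)cc2)o1` arises from compound 1 by the change (methylsulfonyl in place of 6-carboxypyridin-3-yl on an aromatic carbon), which keeps the ketone but trades the aryl acid for a small sulfone. Among the measured compounds shown here, no measured pair covers this change; the step from compound 1 to compound 3 is expected to be a 5.7-fold higher number from compound 1 to compound 3 (0.75 log units; beyond the scatter), a weakening beyond the scatter. Compound 3 is estimated at 250 nM, within 60 nM to 1200 nM.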

Compound 3, inhibition constant: 1.2 nM
Compound 3: middle estimate off by 210-fold (2.32 log units), on the high side; measured number below the stated range.
By their numbers in this assay, from the lowest: compound 3; then compound 1; then compound 2.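

In this assay, putting methylsulfonyl in place of 6-carboxypyridin-3-yl on the aromatic carbon next to the ring oxygen gives a 37-fold lower number from compound 1 to compound 3 (1.56 log units; beyond the scatter). This position therefore does not need the larger ring-bearing group of compound 1: a group of 4 heavy atoms with no ring gives the lowest number of the three compounds. No measurement shown explains this gain.

Going by these compounds, it remains open whether a nitrile or an amide on this carbon would match methylsulfonyl. Also open, on these data alone, is what a hydroxyl in place of the ketone would do to compound 3 alone.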